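Swapping an Imidazole for a Methyl Carbamate

A few compounds are considered here, and "the series" means these few. Any claim that something is new, unique, unknown or untested is made for them only; others in the source may bear on it.

This study measures how well small molecules dissolve, in a physicochemical assay for solubility, read by HPLC, with a stated time of 24 h; a higher number here means a more soluble compound, a lower number a less soluble compound. Compound 1 `O=C1O[C@@H](CN2CCC(O)CC2)CN1c1ccc(-n2cc(-c3ccccn3)cn2)c(F)c1` gives 45900 nM, and compound 2 `O=C1O[C@@H](Cn2ccnc2)CN1c1ccc(-n2cc(-c3ccccn3)cn2)c(F)c1` gives 12300 nM. Going by the values given here, compound 2 thus stands at the lower of the two numbers so far; the only measured step, a 3.7-fold lower number from compound 1 to compound 2 (0.57 log units; beyond the scatter), separates it from compound 1.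

The next compound, compound 3 `COC(=O)NC[C@H]1CN(c2ccc(-n3cc(-c4ccccn4)cn3)c(F)c2)C(=O)O1`, differs from compound 2 in one place: (methoxycarbonyl)amino in place of 1H-imidazol-1-yl on a saturated chain carbon bound to a saturated ring carbon. Among the compounds with values here, no measured step covers this particular exchange. Within the data shown here, the one step available, a 3.7-fold lower number from compound 1 to compound 2 (0.57 log units; beyond the scatter), concerns a different pair of groups at the same position, so it shows only that a change at this place can shift the number modestly. On that basis, compound 3 is expected to land near compound 2, with any step a 1.2-fold lower number from compound 2 to compound 3 (0.09 log units; within the scatter) unlikely to reach beyond the usual scatter. The estimate for compound 3 is therefore 10000 nM, with a plausible range from 3000 nM to 40000 nM.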

Compound 3, solubility: 34100 nM
Compound 3: middle estimate off by 3.4-fold (0.53 log units), on the low side; measured number inside the range.
By their numbers in this assay, from the lowest: compound 2; then compounds 3 and 1 (each within the scatter of the next).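

The step of a 2.8-fold higher number from compound 2 to compound 3 (0.44 log units; beyond the scatter) in this assay shows that this place on a saturated chain carbon bound to a saturated ring carbon responds to more than the size of the group, since 1H-imidazol-1-yl and (methoxycarbonyl)amino each have 5 heavy atoms yet the two compounds still differ beyond the scatter. The step of a 1.3-fold lower number from compound 1 to compound 3 (0.13 log units; within the scatter) stays within the scatter, so the open-chain (methoxycarbonyl)amino and the ring of 4-hydroxypiperidin-1-yl cannot be told apart here, and compound 2, the only one of the three with a five-membered aromatic ring at this place, has the lowest number. No measurement shown accounts for why these groups give these numbers.

Going by these compounds alone, with only three groups at this place, it remains open whether the low number belongs to 1H-imidazol-1-yl alone or would also appear with another five-membered aromatic ring, such as a 1,2,3-triazole. From the compounds shown here alone, it is also open how a simple primary amine, a carboxylic acid or a longer chain carrying the same methoxycarbonyl group would compare with compound 3.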